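Amine substituent replacement on compound 2

The compounds below may be only part of what the source reports. "The series", "measured", "known", "first", "only" and "open" are said of these compounds alone.

Measured in a functional assay on CCRF-CEM cells for antagonist activity at C-X-C chemokine receptor type 4 (Homo sapiens), read by calcium flux, with stated times of 25 min and 90 s; on this read-out lower numbers stand for stronger inhibition and higher numbers for weaker inhibition:
- compound 1 `CN1CCN(Nc2cccc3c2C[C@@H](CN(C)[C@H]2CCCc4cccnc42)NC3)CC1`: 47.4 nM
- compound 2 `CN(C[C@H]1Cc2c(cccc2N[C@H]2CC[C@H](N)CC2)CN1)[C@H]1CCCc2cccnc21`: 755 nM
- compound 3 `CN1C[C@@H]2CN(c3cccc4c3C[C@H](CN(C)[C@H]3CCCc5cccnc53)NC4)C[C@@H]2C1`: 9.56 nM

Compound 2 stands highest of the three numbers; compound 1 lies well below it, and compound 3 lies lowest of all, both gaps beyond the scatter. The unmeasured compound 4 `CN(C)C1CCN(c2cccc3c2C[C@H](CN(C)[C@H]2CCCc4cccnc42)NC3)CC1` differs from compound 2 in one place: 4-(dimethylamino)piperidin-1-yl in place of (4-aminocyclohexyl)amino on an aromatic carbon. Among the measured compounds shown here, one measured step bears directly on this change, since it starts from the same compound 2 and likewise replaces the (4-aminocyclohexyl)amino by a ring nitrogen attached to the aromatic carbon: a 79-fold lower number from compound 2 to compound 3 (1.90 log units; beyond the scatter). The entering group in compound 4 is a single six-membered ring with one hetero atom rather than the two five-membered rings of compound 3, so the full size of that step need not carry over, but a large step toward lower numbers in this assay is expected. For compound 4 the estimate is 40 nM (range 10 nM to 160 nM), which is expected to mean a 19-fold lower number from compound 2 to compound 4 (1.28 log units; beyond the scatter).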

Compound 4, half-maximal inhibitory concentration: 35.9 nM
The estimate for compound 4 lay 1.1-fold (0.05 log units) above the measured number, within the range that was stated.
By their numbers in this assay, from the lowest: compound 3; then compounds 4 and 1 (each within the scatter of the next); then compound 2.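

In this assay, the large drop seen with compound 3 is not confined to its two five-membered rings, since a single 4-(dimethylamino)piperidin-1-yl on the same aromatic carbon also gives a large step (a 21-fold lower number from compound 2 to compound 4 (1.32 log units; beyond the scatter)). The ring architecture of the entering group still matters at this position, though only modestly, with the step beyond the scatter (a 3.8-fold higher number from compound 3 to compound 4 (0.57 log units; beyond the scatter)). No measurement is at hand that accounts for either step.

As far as these compounds go, the change to compound 4 alters the ring, the attachment to the aromatic carbon and the hydrogen-bond donor count (2 leaving, 0 entering) together, so the contribution of each remains open. A 4-aminopiperidin-1-yl group on the same aromatic carbon would separate the attachment through the ring nitrogen from the dimethylamino substitution.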